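The compounds below may be only part of what the source reports. "The series", "measured", "known", "first", "only" and "open" are said of these compounds alone.

Three compounds share one core. Compound 1 `O=C1CSC(c2cccc(Cl)c2)N1CCN1CCCCC1` gives 77% in an ADME assay on Vero cells (Chlorocebus sabaeus) for cytotoxicity, read by neutral red uptake, tested at 197 ug/mL; on this read-out higher numbers stand for a weaker effect at the one concentration tested and lower numbers for a stronger effect; compound 2 `O=C1CSC(c2ccc(O)cc2)N1CCN1CCCCC1` gives 87% in this assay; compound 3 `COc1ccccc1C1SCC(=O)N1CCN1CCCCC1` gives 72% in this assay. Compound 2 and compound 1 lie within the scatter of each other, whereas compound 3 sits beyond the scatter, lower than compound 2. Compound 4 `O=C1CSC(c2ccc(F)cc2)N1CCN1CCCCC1` is not yet measured. It differs from compound 2 by fluoro in place of hydroxy on an aromatic carbon. Among the compounds with values here, the one measured step that alters this aryl group, a number 10 percentage points higher from compound 1 to compound 2 (within the scatter), stayed within the scatter; compound 3, which also lacks the hydroxy, gives a lower number. The change is therefore expected to move the number little, if anything slightly downward: a number 9 percentage points lower from compound 2 to compound 4 (within the scatter). The expected value for compound 4 is 78%, within 63% to 92%.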

Compound 4, a percentage reported as activity, at one concentration (the size of the read-out at that concentration, not a potency): 73%
For compound 4 the middle estimate is 5 percentage points above the measured one, within the range that was stated.
By their numbers in this assay, from the lowest: compounds 3, 4, 1 and 2 (each within the scatter of the next, the first and the last beyond it).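

In this assay, within the data shown here, fluoro in place of hydroxy on this aromatic carbon gives a number 14 percentage points lower from compound 2 to compound 4 (beyond the scatter), the first step at this aryl group to pass the scatter, though only modestly. The other new step, a number 4 percentage points lower from compound 1 to compound 4 (within the scatter), does not separate the 4-fluorophenyl and 3-chlorophenyl groups, so compound 2 stands apart from compound 4 but not from compound 1. Nothing measured here explains the step from hydroxy to fluoro.

As far as these compounds go, it remains open whether an amine or a carboxylic acid on this aromatic carbon would give a number nearer that of compound 2 or compound 4. From the compounds shown here alone, the effect of moving one group around the ring, with the group itself unchanged, also remains open.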